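Isoquinolinone to isoquinoline on the urea nitrogen

The source may hold more compounds than are shown below. What is called first, only, known or untested is meant among the compounds shown, and "the series" means these compounds.

Among the measured compounds shown here, compound 2 `CN(C)C1(Cc2ccccc2)CCN(c2cc(C(F)(F)F)ccc2CNC(=O)Nc2cccc3c(=O)[nH]ccc23)CC1` gives 111 nM in an assay on CHO cells for displacement of a labelled ligand from transient receptor potential cation channel subfamily V member 1 (Homo sapiens), read by scintillation counting, with a stated time of 60 min (on this read-out higher numbers stand for weaker inhibition and lower numbers for stronger inhibition), the highest of the two numbers measured so far, while compound 1 `CN(C)C1(Cc2ccccc2)CCN(c2cc(C(F)(F)F)ccc2CNC(=O)Nc2ccc(CO)c(F)c2)CC1` gives 27.9 nM; the single measured step, a 4.0-fold higher number from compound 1 to compound 2 (0.60 log units; beyond the scatter), is the only guide. Compound 3 `CN(C)C1(Cc2ccccc2)CCN(c2cc(C(F)(F)F)ccc2CNC(=O)Nc2cccc3ccncc23)CC1` differs from compound 2 by a group of 10 heavy atoms (9 carbon, 1 nitrogen; one six-membered aromatic ring of carbon only, one six-membered aromatic ring with 1 hetero atom) in place of a group of 11 heavy atoms (9 carbon, 1 nitrogen, 1 oxygen; one six-membered aromatic ring of carbon only, one six-membered aromatic ring with 1 hetero atom), on an amide-type nitrogen. For the measured compounds named here, no measured step changes the group on the amide-type nitrogen in this way, so the earlier step gives only a rough scale and no direction. Compound 3 is therefore expected close to its parent, with an expected step of a 1.0-fold lower number from compound 2 to compound 3 (0.00 log units; within the scatter). For compound 3 the estimate is 110 nM, with a range from 30 nM to 400 nM.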

Compound 3, inhibition constant: 12.3 nM
Beside the measured number, compound 3's estimate is 8.9-fold (0.95 log units) above it; measured number outside the range, below it.
By their numbers in this assay, from the lowest: compound 3; then compound 1; then compound 2.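

Exchanging the group on the amide-type nitrogen for isoquinolin-8-yl, which has 0 hydrogen-bond donors against 1 in the group it replaces, gives a 9.0-fold lower number from compound 2 to compound 3 (0.96 log units; beyond the scatter) in this assay, so this position responds strongly to a change that keeps both six-membered aromatic rings. Isoquinolin-8-yl in place of 3-fluoro-4-(hydroxymethyl)phenyl also gives a 2.3-fold lower number from compound 1 to compound 3 (0.36 log units; beyond the scatter). No measurement at hand accounts for these steps.

From the compounds shown here alone, it remains open whether the ring nitrogen of isoquinolin-8-yl is needed or a naphthyl group would serve equally well. How an amine or a methoxy group on that ring system would fare is also unresolved.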